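The source may hold more compounds than are shown below. What is called first, only, known or untested is meant among the compounds shown, and "the series" means these compounds.

Measured in a functional assay on HT-29 cells (Homo sapiens) for cytotoxicity, read by sulforhodamine B assay, with a stated time of 72 h; a higher number here means a weaker inhibitor, a lower number a stronger inhibitor:
Compound 1 `COc1cc2ncnc(Nc3ccc(F)c(Cl)c3)c2cc1OCCCCn1ccnc1[N+](=O)[O-]` gives 2210 nM.
Compound 2 `C#Cc1cccc(Nc2ncnc3cc(OC)c(OCCCCn4ccnc4[N+](=O)[O-])cc23)c1` gives 10100 nM.
Compound 3 `COc1cc2ncnc(Nc3ccc(OCc4cccc(F)c4)c(Cl)c3)c2cc1OCCCn1ccnc1[N+](=O)[O-]` gives 15500 nM.

Compound 3 carries the highest number of the three; its gap to compound 2 lies within the scatter, while compound 1 sits well below it. Compound 4 `COc1cc2ncnc(Nc3ccc(OCc4cccc(F)c4)c(Cl)c3)c2cc1OCCCCn1ccnc1[N+](=O)[O-]` differs from compound 3 by (2-nitro-1H-imidazol-1-yl)methyl in place of 2-nitro-1H-imidazol-1-yl on a saturated chain carbon, three bonds along the chain from an oxygen on an aromatic ring, a lengthening of the linker chain. Within the data shown here, no measured step covers this change: the only step, a 4.6-fold higher number from compound 1 to compound 2 (0.66 log units; beyond the scatter), swaps the aniline group instead, and compounds 1 and 3 differ in both the aniline and the chain, so their gap cannot be assigned to either part. With nothing to go on, compound 4 is expected to sit close to compound 3, the step of a 1.1-fold lower number from compound 3 to compound 4 (0.04 log units; within the scatter) being within the scatter. Compound 4 is estimated at 14000 nM, in the range 5000 nM to 40000 nM.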

Compound 4, half-maximal inhibitory concentration: 1870 nM
Estimate against measurement, compound 4: 7.5-fold (0.87 log units) above; measured number below the stated range.
By their numbers in this assay, from the lowest: compounds 4 and 1 (each within the scatter of the next); then compounds 2 and 3 (each within the scatter of the next).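

In this assay, extending the linker from the 2-nitro-1H-imidazol-1-yl end by one methyl unit gives a change beyond the scatter (an 8.3-fold lower number from compound 3 to compound 4 (0.92 log units; beyond the scatter)), so this chain position matters in a way the earlier aniline step could not show. With the longer chain held constant, (3-fluorobenzyl)oxy in place of fluoro on an aromatic carbon stays within the scatter (a 1.2-fold lower number from compound 1 to compound 4 (0.07 log units; within the scatter)). Nothing available explains the effect of the chain change. From the compounds shown here alone, whether a longer chain, or an amine in place of 2-nitro-1H-imidazol-1-yl, would keep the lower number remains open.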